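The source may hold more compounds than are shown below. What is called first, only, known or untested is meant among the compounds shown, and "the series" means these compounds.

Compound 1 `O=C(O[C@H]1C[C@H](n2cc(F)c(=O)[nH]c2=O)O[C@@H]1COP(=O)(O)Oc1ccccc1)c1ccccc1` and compound 2 `O=C(O[C@H]1C[C@H](n2cc(F)c(=O)[nH]c2=O)O[C@@H]1COP(=O)(O)Oc1cccnc1)c1ccccc1` share one core and differ only in the aryl group attached to the phosphate oxygen. In a physicochemical assay for metabolic stability, read by HPLC, tested at 2 mM (on this read-out higher numbers stand for a longer-lived compound and lower numbers for a shorter-lived compound), compound 1 gives 6.6 h, and compound 2 gives 6.7 h. Within the data shown here, the single step measured so far, a 1.0-fold higher number from compound 1 to compound 2 (0.01 log units; within the scatter), shows that putting pyridin-3-yl in place of phenyl on that oxygen left the half-life untouched. Of the two numbers shown, compound 2 nominally occupies the top spot, but since its step from compound 1 lies within the scatter, the two compounds cannot be told apart in this assay.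

Compound 3 `O=C(O[C@H]1C[C@H](n2cc(F)c(=O)[nH]c2=O)O[C@@H]1COP(=O)(O)Oc1ccc2ncccc2c1)c1ccccc1` continues at the same oxygen: quinolin-6-yl in place of pyridin-3-yl on an oxygen. Among the measured compounds shown here, the only measured step that bears on this change is the flat one from compound 1 to compound 2 at the same position. For the measured compounds named here, that step was within the scatter, and no measured pair shows what the quinolin-6-yl group does here, so the expectation for compound 3 in this assay is a step of about no change at the digits printed from compound 2 to compound 3 (within the scatter), that is, none beyond the scatter. Compound 3 is accordingly estimated at 6.7 h, with a plausible range from 3.5 h to 13 h.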

Compound 3, half-life: 7.7 h
Compound 3: the middle estimate sits 1.1-fold (0.06 log units) below what was measured, and the stated range covers the measured number.
By their numbers in this assay, from the lowest: compounds 1, 2 and 3 (each within the scatter of the next).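

Exchanging pyridin-3-yl for quinolin-6-yl on the oxygen bound to phosphorus takes the group from 6 to 10 heavy atoms and adds one six-membered aromatic ring of carbon only, yet this assay shows only a 1.1-fold higher number from compound 2 to compound 3 (0.06 log units; within the scatter), and the comparison with the phenyl group shows a 1.2-fold higher number from compound 1 to compound 3 (0.07 log units; within the scatter). The earlier pair had shown only that one six-membered aromatic ring could replace another at this oxygen, whereas these steps show that the half-life cannot be told apart across a clearly larger aromatic group as well, and none of the three compounds goes against this. The data at hand offer no explanation for this flat behaviour.

From the compounds shown here alone, all three groups on this oxygen are uncharged aromatic groups, so it remains open whether an aryl group carrying an amine or a carboxylic acid, or a plain alkyl chain in its place, would shift the half-life beyond the scatter. The rest of the core is the same in all three compounds, so they also do not show whether the half-life responds to a change elsewhere in the molecule.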